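Swapping the Aryl Group on a Shared Core

The source may hold more compounds than are shown below. What is called first, only, known or untested is meant among the compounds shown, and "the series" means these compounds.

Measured so far, in a functional assay on HL-60 cells (Homo sapiens) for antiproliferative activity, read by MTT assay, with a stated time of 72 h; a higher number here means a weaker inhibitor, a lower number a stronger inhibitor:
- compound 1, `NC1=NC2(CCOCC2)N(OCCCOc2ccc(F)cc2)C(N)=N1`, gives 2380 nM
- compound 2, `NC1=NC2(CCOCC2)N(OCCCOc2ccccc2Cl)C(N)=N1`, gives 660 nM
- compound 3, `CC(C)(C)c1ccc(OCCCON2C(N)=NC(N)=NC23CCOCC3)cc1`, gives 870 nM

Compound 2 has the lowest of the three numbers in this assay, but its nearest neighbour, compound 3, lies within the usual scatter of it, so the two cannot be ranked; only compound 1 stands apart, with a number that is higher beyond the scatter.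

Compound 4, `Cc1cc(C)cc(OCCCON2C(N)=NC(N)=NC23CCOCC3)c1`, has not yet been measured. It differs from compound 2 in one place: 3,5-dimethylphenyl in place of 2-chlorophenyl on an oxygen on a saturated carbon.

Going by the values given here, two measured steps touch the same aryl group. Moving from compound 1 to compound 2 gave a 3.6-fold lower number from compound 1 to compound 2 (0.56 log units; beyond the scatter), and moving from compound 1 to compound 3 gave a 2.7-fold lower number from compound 1 to compound 3 (0.44 log units; beyond the scatter). Both show that replacing the fluorophenyl of compound 1 with a larger aryl group lowers the number, yet neither tells how a dimethylphenyl compares with a chlorophenyl; compound 3 with its tert-butyl group is the closest hint, and its number sits within the scatter of compound 2.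

For compound 4 in this assay, a number close to compound 2 is therefore expected, with the step of a 1.2-fold higher number from compound 2 to compound 4 (0.08 log units; within the scatter) staying within the scatter. The estimate for compound 4 is 800 nM, with a range from 350 nM to 1800 nM.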

Compound 4, half-maximal inhibitory concentration: 720 nM
For compound 4 the middle estimate is 1.1-fold (0.05 log units) above the measured one, within the range that was stated.
By their numbers in this assay, from the lowest: compounds 2, 4 and 3 (each within the scatter of the next); then compound 1.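

In this assay, the step of a 1.1-fold higher number from compound 2 to compound 4 (0.04 log units; within the scatter) shows that 3,5-dimethylphenyl can stand in place of 2-chlorophenyl at this position with no change that can be told from the scatter, even though the chlorine is gone and the entering group has one more heavy atom. The step of a 3.3-fold lower number from compound 1 to compound 4 (0.52 log units; beyond the scatter) places compound 4 with compound 2 and compound 3, so a third aryl group now has a number clearly lower than that of compound 1, and none of the four goes against this. No measurement here explains why these aryl groups give such similar numbers or why the 4-fluorophenyl compound stands apart.

The compounds shown leave open how an unsubstituted phenyl would compare. They also leave open whether an aryl group carrying an amine or a carboxylic acid, or a longer chain, would keep the number in this range.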